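Trimming a Bulky Tail: Compound 2 to Compound 3

The source may report more compounds than this note shows. Statements on the series, on what has been measured and on what is new or still open speak of the compounds shown alone.

Compound 2 `COC(=O)c1cccc(NC(=O)COc2ccc(C(C)(C)CC(C)(C)C)cc2)c1` holds the lowest of the two numbers measured in an assay for inhibition of malate dehydrogenase, cytoplasmic (Homo sapiens), with a stated time of 30 min; on this read-out higher numbers stand for weaker inhibition and lower numbers for stronger inhibition. In this assay compound 2 gives 6650 nM, while compound 1 `COCCOc1ccc(C(=O)OC)cc1NC(=O)COc1ccc(C(C)(C)CC(C)(C)C)cc1` gives 18400 nM. Going by the values given here, the only measured step, a 2.8-fold lower number from compound 1 to compound 2 (0.44 log units; beyond the scatter), concerns the 2-methoxyethoxy group on one aromatic ring and does not touch the other end of the molecule.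

Compound 3 `COC(=O)c1cccc(NC(=O)COc2ccc(C)cc2)c1` differs from compound 2 by methyl in place of 1,1,3,3-tetramethylbutyl on an aromatic carbon. Among the compounds with values here, no measured step bears on this position, so the expectation rests on compound 2 alone and on the size of what is removed. A step toward a higher number, that is weaker inhibition, is expected, and its size is uncertain. The estimated step of a 4.5-fold higher number from compound 2 to compound 3 (0.65 log units; beyond the scatter) is therefore tentative. For compound 3 in this assay the estimate is 30000 nM, with a range from 8000 nM to 120000 nM.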

Compound 3, half-maximal inhibitory concentration: > 40000 nM
Compound 3 was reported as a limit (the forecaster's own chance of this, stated with the estimate: 25%); at least 1.3-fold (0.12 log units) between middle value and limit.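

Compound 1 and compound 2 both carry the 1,1,3,3-tetramethylbutyl group, so neither could show whether it matters. Putting methyl in its place gives an at least 6.0-fold higher number from compound 2 to compound 3 (0.77 log units; beyond the scatter) and so shows that this end of the molecule, far from the 2-methoxyethoxy change, also counts for inhibition in this assay here. The result for compound 3 is a limit and not a measured number, so the step sets only a floor on the size of the change: the limit of > 40000 nM in this assay, at which 1 of the 3 values shown sits.

The compounds shown leave open how inhibition changes between these two extremes, for instance with an ethyl, a tert-butyl or a longer straight chain at this place. They also leave open whether a cyclohexyl ring, an amine or a carboxylic acid could stand there.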